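The compounds below may be only part of what the source reports. "The series", "measured", "known", "first", "only" and "open" are said of these compounds alone.

In a functional assay on HCT-116 cells (Homo sapiens) for antiproliferative activity, read by MTT assay, with a stated time of 72 h (a higher number here means a weaker inhibitor, a lower number a stronger inhibitor), compound 1 (`NC1=NC2(CCOCC2)N(OCCCOc2ccccc2)C(N)=N1`) gives 6010 nM as the higher of the two measured numbers, and compound 2 (`NC1=NC2(CCOCC2)N(OCCCOc2cccc(Cl)c2Cl)C(N)=N1`) gives 5 nM as the lower one. Compound 3 (`CC(C)(C)c1ccc(OCCCON2C(N)=NC(N)=NC23CCOCC3)cc1`) is still unmeasured and differs from compound 1 by tert-butyl in place of hydrogen on an aromatic carbon. For the measured compounds named here, the only measured step that bears on this change is a 1200-fold lower number from compound 1 to compound 2 (3.08 log units; beyond the scatter) for 2,3-dichlorophenyl in place of phenyl, which is large and beyond the scatter. A different group enters here, so a smaller step towards a lower number is expected in this assay (a 60-fold lower number from compound 1 to compound 3 (1.78 log units; beyond the scatter)). Compound 3 is estimated to lie between 10 nM and 1500 nM with 100 nM as the middle value.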

Compound 3, half-maximal inhibitory concentration: 1610 nM
Compound 3: middle estimate off by 16-fold (1.21 log units), on the low side; measured number outside the range, above it.
By their numbers in this assay, from the lowest: compound 2; then compound 3; then compound 1.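

In this assay, tert-butyl on an aromatic carbon, para to a large group, gives a 3.7-fold lower number from compound 1 to compound 3 (0.57 log units; beyond the scatter), so this change lowers the number beyond the scatter, but only modestly. The 2,3-dichlorophenyl change gives a much larger step, a 1200-fold lower number from compound 1 to compound 2 (3.08 log units; beyond the scatter), so changes on the phenyl ring can differ greatly in size. Nothing measured here explains that difference. The compounds shown leave open whether a methoxy group or an amine at the same place would give a step closer to the modest one or the large one.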